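The source may hold more compounds than are shown below. What is called first, only, known or untested is meant among the compounds shown, and "the series" means these compounds.

Compound 1, with the structure `CC(CO)NCCOc1c(O)cc(O)c2c(=O)cc(-c3ccccc3)oc12`, is the starting point of this comparison, yet in a functional assay on A549 cells (Homo sapiens) for cytotoxicity, read by MTT assay, with a stated time of 48 h (a lower number here means a stronger inhibitor, a higher number a weaker inhibitor), compound 1 gives "not determined" (no result reported), so no single number places it on the scale. Within the data shown here, the only measured anchor is compound 2, with the structure `COc1c(OCCCNCc2ccccc2)cc(O)c2c(=O)cc(-c3ccccc3)oc12`; in this assay compound 2 gives 1570 nM. Compound 3, with the structure `CN(C)CCCOc1c(O)cc(O)c2c(=O)cc(-c3ccccc3)oc12`, has not yet been tested. The change from compound 1 to compound 3 is (dimethylamino)methyl in place of (1-(hydroxymethyl)ethyl)amino on a saturated chain carbon, two bonds along the chain from an oxygen on an aromatic ring, a change on a saturated chain carbon, two bonds along the chain from an oxygen on an aromatic ring. Among the measured compounds shown here, no step between two measured compounds covers this change, so its size cannot be read from the data; the author expects any shift from compound 1 to compound 3 in this assay to be modest, within or only slightly beyond the scatter, without a firm direction. On the strength of what compound 2 shows, compound 3 is expected to reach about 3000 nM in this assay, with a plausible range from 700 nM to 15000 nM.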

Compound 3, half-maximal inhibitory concentration: > 100000 nM
Compound 3 was reported as a limit; the forecaster's own chance of this, stated with the estimate: 15%; middle value at least 33-fold (1.52 log units) from the limit.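

Compound 3 gives > 100000 nM in this assay, which is a limit of the assay and not a number. Among these compounds, compound 1 has no single number there, so no new step from compound 1 to compound 3 can be read. The compounds shown leave open how far 3-(dimethylamino)propoxy in place of 2-((1-(hydroxymethyl)ethyl)amino)ethoxy moves this result.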